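This account rests on a few compounds, and the source may have more. Where it says the series, first, only, none or still open, it means among the compounds named here.

Compound 1 `COc1ccc(-c2cs/c(=N/NC(=O)CSc3nnnn3-c3ccccc3)n2-c2ccccc2)cc1` carries a 1-phenyl-1H-tetrazol-5-yl on a sulfur. In an ADME assay on NIH3T3 cells (Mus musculus) for cytotoxicity, read by MTT assay, with a stated time of 24 h (a higher number here means a weaker inhibitor, a lower number a stronger inhibitor), compound 1 gives 11.7 ug/mL, the lowest of the three numbers. Compound 2 `COc1ccc(-c2cs/c(=N/NC(=O)CSc3ncccn3)n2-c2ccccc2)cc1` gives 450 ug/mL and compound 3 `COc1ccc(-c2cs/c(=N/NC(=O)CSc3nnc(C)s3)n2-c2ccccc2)cc1` gives 300 ug/mL; the steps of a 38-fold higher number from compound 1 to compound 2 (1.59 log units; beyond the scatter) and a 26-fold higher number from compound 1 to compound 3 (1.41 log units; beyond the scatter) are large, while a 1.5-fold lower number from compound 2 to compound 3 (0.18 log units; within the scatter) lies within the scatter. Compound 4 `O=C(CSc1nnnn1-c1ccccc1)N/N=c1/scc(-c2ccc(Br)cc2)n1-c1ccccc1` differs from compound 1 by bromo in place of methoxy on an aromatic carbon. Within the data shown here, none of the measured steps touches this part of the molecule; all three change the group on the sulfur, which compound 4 keeps. Among the measured compounds shown here, no measured step therefore bears on the change, and the expected step of a 1.3-fold higher number from compound 1 to compound 4 (0.11 log units; within the scatter) is none beyond the scatter. In this assay compound 4 is expected to give 15 ug/mL, between 5 ug/mL and 45 ug/mL.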

Compound 4, half-maximal inhibitory concentration: 433 ug/mL
The estimate for compound 4 lay 29-fold (1.46 log units) below the measured number, outside the stated range (above it).
By their numbers in this assay, from the lowest: compound 1; then compounds 3, 4 and 2 (each within the scatter of the next).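

In this assay, the aromatic carbon para to a large group proves sensitive: bromo in place of methoxy gives a 37-fold higher number from compound 1 to compound 4 (1.57 log units; beyond the scatter) and so removes the low number of compound 1. A change here, with the group on the sulfur kept, is thus a large step, of the same class as a 38-fold higher number from compound 1 to compound 2 (1.59 log units; beyond the scatter) on the sulfur. Nothing available explains this step. Still open, going by these compounds, is what an amine, a hydroxyl or a chloro on this carbon would give. Also open, on these data alone, is whether bromo acts alike with pyrimidin-2-yl on the sulfur.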